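A few compounds are considered here, and "the series" means these few. Any claim that something is new, unique, unknown or untested is made for them only; others in the source may bear on it.

Measured so far:
compound 1 `CN(C)CCCn1c(N)c(-c2nc3ccccc3[nH]2)c2nc(C#N)c(C#N)nc21` — 870 nM
compound 2 `CCN(CC)CCCn1c(N)c(-c2nc3ccccc3[nH]2)c2nc(C#N)c(C#N)nc21` — > 730 nM
compound 3 `CN(C)CCn1c(N)c(-c2nc3ccccc3n2C)c2nc(C#N)c(C#N)nc21` — > 50000 nM

In a functional assay on HL-60 cells (Homo sapiens) for antiproliferative activity, read by MTT assay, with a stated time of 48 h (a lower number here means a stronger inhibitor, a higher number a weaker inhibitor), compound 1 gives 870 nM. For compound 2 this assay reports only a limit, > 730 nM. The change between them, (diethylamino in place of dimethylamino on a saturated chain carbon, three bonds along the chain from an aromatic nitrogen), therefore gives a step that the limit leaves unreadable from compound 1 to compound 2, unreadable because the limit of > 730 nM in this assay, at which 1 of the 3 values shown sits, sits over the second value. Compound 3 also stands only at a limit in this assay, > 50000 nM, which is the limit of > 50000 nM in this assay, at which 1 of the 3 values shown sits. How the core of compound 3 differs from that of compound 1 is not broken down here. Compound 4 `CCN(CC)CCn1c(N)c(-c2nc3ccccc3n2C)c2nc(C#N)c(C#N)nc21` is to be measured in this assay. It carries diethylamino in place of dimethylamino on a saturated chain carbon, two bonds along the chain from an aromatic nitrogen, the same kind of change as in the first pair, but two bonds along the chain from an aromatic nitrogen rather than three. Since the measured step of that kind left no readable size, compound 4 is expected to stay near compound 3, an expected step of a number no higher from compound 3 to compound 4 (the limit leaves the size open). The estimate for compound 4 is 50000 nM, expected between 15000 nM and 100000 nM, most likely again only a limit.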

Compound 4, half-maximal inhibitory concentration: 8800 nM
Estimate against measurement, compound 4: 5.7-fold (0.75 log units) above, outside the stated range (below it).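

In this assay, diethylamino in place of dimethylamino gives an at least 5.6-fold lower number from compound 3 to compound 4 (0.75 log units; beyond the scatter), so on the core of compound 3 this change lowers the number, and the step is a minimum rather than an exact size. On the core of compound 1 the same change gives a step that cannot be read, because compound 2 stands only at a limit: the limit of > 730 nM in this assay, at which 1 of the 4 values shown sits. This shows the change lowering the number on one core only, and it does not show whether that gain carries over to the other core.

From the compounds shown here alone, what a pyrrolidine ring or a morpholine ring in place of diethylamino would do stays open on both cores. So does the effect of a dipropylamino group, a larger amine of the same open-chain kind.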